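The source may hold more compounds than are shown below. What is called first, only, known or untested is meant among the compounds shown, and "the series" means these compounds.

Within the data shown here, the three compounds measured so far share one core and differ only in the group on the outer aromatic ring. Compound 1 `Cc1ccc(C(=O)/C=C/c2ccc3c(c2)B(O)OC3)cc1` carries a methyl. In an ADME assay on L929 cells (Mus musculus) for cytotoxicity, read by resazurin assay, with a stated time of 72 h (a higher number here means a weaker inhibitor, a lower number a stronger inhibitor), compound 1 gives > 10 ug/mL, which is a limit of the assay rather than a number. Compound 2 `COc1ccccc1C(=O)/C=C/c1ccc2c(c1)B(O)OC2` carries a methoxy, and in this assay compound 2 gives 6.35 ug/mL. Compound 3 `O=C(/C=C/c1ccc2c(c1)B(O)OC2)c1ccc(OCc2ccccc2)cc1` carries a benzyloxy. In this assay compound 3 gives > 10 ug/mL, again a limit of the assay rather than a number. Compound 3 thus stands at the limit of > 10 ug/mL in this assay, at which 2 of the 3 values shown sit. Among the measured compounds shown here, the only measured step that touches compound 3 is a step that the two limits leave unreadable from compound 1 to compound 3, whose size the two limits leave unreadable. The next compound is compound 4 `O=C(/C=C/c1ccc2c(c1)B(O)OC2)c1ccc([N+](=O)[O-])cc1`, and its change from compound 3 is nitro in place of benzyloxy on an aromatic carbon. For the measured compounds named here, no measured step pairs a nitro with any other group, so the measured steps give neither size nor direction. Compound 4 is therefore expected to give about 10 ug/mL in this assay, within a range from 4 ug/mL to 25 ug/mL. The estimated step is a number no higher from compound 3 to compound 4 (the limit leaves the size open), none beyond the scatter.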

Compound 4, half-maximal inhibitory concentration: > 10 ug/mL
Compound 4 ended at the assay's limit; the forecaster's own chance of this, stated with the estimate: 55%; the middle value sits exactly at the limit.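

No step among compound 1, compound 3 and compound 4 can be read in this assay, because all three stand at a limit of the assay rather than at a number: the limit of > 10 ug/mL in this assay, at which 3 of the 4 values shown sit.

The compounds shown leave open whether the methyl, benzyloxy and nitro groups differ from one another at all in this assay.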